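The source may report more compounds than this note shows. Statements on the series, on what has been measured and on what is new or still open speak of the compounds shown alone.

Measured in a functional assay on MCF7 cells (Homo sapiens) for antiproliferative activity, read by CellTiter-Glo, with a stated time of 5 days; on this read-out lower numbers stand for stronger inhibition and higher numbers for weaker inhibition:
- compound 1 `CC1=C(c2cccc(O)c2)C(c2ccc(OC[C@H](C)N3CCCCC3)cc2)Oc2ccc(O)cc21`: 0.1 nM
- compound 2 `CC1=C(c2cccc(O)c2)[C@@H](c2ccc(OC[C@H](C)N3CC[C@@H](C)C3)cc2)Oc2ccc(O)cc21`: 59 nM
- compound 3 `CC1=C(c2cccc(O)c2)C(c2ccc(OC[C@@H](C)N3CC[C@H](C)C3)cc2)Oc2ccc(O)cc21`: 0.2 nM

Compound 3 stands level with compound 1 and far under compound 2 on these numbers. The next compound, compound 4 `CC1=C(c2cccc(O)c2)C(c2ccc(OC[C@H](C)N3CC[C@H](C)C3)cc2)Oc2ccc(O)cc21`, is related to compound 3 as follows: the two compounds have the same atoms and bonds; at least one stereo element is drawn with a configuration in one of them and without one in the other: 1 of 3 stereo elements differ; a stereocentre at a saturated chain carbon is drawn R in compound 3 and S in compound 4. Only the saturated chain carbon changes, from R in compound 3 to S in compound 4.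

Among the measured compounds shown here, two measured steps bear on this change. The first is a 2.0-fold higher number from compound 1 to compound 3 (0.30 log units; within the scatter), which swaps the amine ring and shows that this part of the molecule can vary without a clear loss in this assay. The second is a 300-fold lower number from compound 2 to compound 3 (2.47 log units; beyond the scatter), which is large and does include the same chain carbon going from S to R. That step, however, alters three stereo elements at once, and it comes with the fact that one of compounds 2 and 3 is drawn with a defined configuration and the other without, at the place where they differ. It therefore gives no clean size for the chain carbon alone, and it leaves open a rise in the number for compound 4.

The central expectation is a small upward move or none beyond the scatter, with more room upward than downward. The expected change is a 1.5-fold higher number from compound 3 to compound 4 (0.18 log units; within the scatter). Compound 4 is estimated at 0.3 nM, with an expected range of 0.08 nM to 3 nM.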

Compound 4, half-maximal inhibitory concentration: 0.2 nM
For compound 4 the middle estimate is 1.5-fold (0.18 log units) above the measured one; the measured number falls inside the stated range.
By their numbers in this assay, from the lowest: compounds 1, 3 and 4 (each within the scatter of the next); then compound 2.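

In this assay, changing the saturated chain carbon alone gives no change at the digits printed from compound 3 to compound 4 (within the scatter), so with the 3-methylpyrrolidin-1-yl group held as drawn, R and S at this carbon cannot be told apart here. Among the compounds shown here, the large gap to compound 2 therefore does not depend on the chain carbon: a 300-fold lower number from compound 2 to compound 4 (2.47 log units; beyond the scatter) remains with that carbon drawn alike, which leaves only the two saturated ring carbons, and this step cannot be divided between them, as only one of the two compounds has a defined configuration at one of those carbons: the fact that one of compounds 2 and 4 is drawn with a defined configuration and the other without, at the place where they differ The step of a 2.0-fold higher number from compound 1 to compound 4 (0.30 log units; within the scatter) shows 3-methylpyrrolidin-1-yl and piperidin-1-yl within the scatter of each other with the chain carbon drawn alike, as the step to the other chain configuration had suggested.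

The compounds shown leave open what each of the two saturated ring carbons contributes alone, including the one drawn R in compound 2 and without a configuration in compound 4. On these data alone, it also remains open whether the chain carbon would stay just as silent with an azepane ring as the amine or an ethyl group in place of the chain methyl.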